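Removing one chloro group from a paired benzyl sulfonamide

This account rests on a few compounds, and the source may have more. Where it says the series, first, only, none or still open, it means among the compounds named here.

Measured so far in a functional assay on CCRF-CEM cells (Homo sapiens) for inhibition; on this read-out lower numbers stand for higher toxicity in this test and higher numbers for lower toxicity in this test:
Compound 1, `O=C1c2ccccc2N(Cc2ccccc2Cl)S(=O)(=O)N1Cc1ccccc1Cl`, gives 40400 nM.
Compound 2, `O=C1c2ccccc2N(Cc2ccccc2Cl)S(=O)(=O)N1Cc1ccccc1`, gives 27900 nM.
Compound 3, `O=C1c2ccccc2N(Cc2ccc(Cl)cc2)S(=O)(=O)N1Cc1ccc(Cl)cc1`, gives 35800 nM.

Compounds 1 and 2 differ in one place: hydrogen in place of chloro on an aromatic carbon. That step made a 1.4-fold lower number from compound 1 to compound 2 (0.16 log units; within the scatter), so the two numbers cannot be told apart with confidence in this assay. Compound 3 carries its two chloro groups on different positions of the same two rings; how its core differs from that of compound 1 is not broken down here. Its value sits close to both of the others, again within the usual scatter.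

Compound 4, `O=C1c2ccccc2N(Cc2ccc(Cl)cc2)S(=O)(=O)N1Cc1ccccc1`, has not yet been measured. It relates to compound 3 as compound 2 relates to compound 1: hydrogen in place of chloro on an aromatic carbon. The change is the same kind of change as before, but not the same, since in compound 1 the chloro that leaves sits ortho to a large group, whereas in compound 3 it sits para to a large group. Going by the values given here, the only guide is the earlier step, which stayed within the scatter, and this rests on one pair alone.

On that basis, compound 4 is expected to give about 28000 nM in this assay, with a plausible range from 14000 nM to 56000 nM. The expected step is a 1.3-fold lower number from compound 3 to compound 4 (0.11 log units; within the scatter), estimated from the modest shift seen between compound 1 and compound 2 and from the weak cytotoxicity of compound 3.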

Compound 4, half-maximal cytotoxic concentration: 19700 nM
The estimate for compound 4 lay 1.4-fold (0.15 log units) above the measured number; the measured number falls inside the stated range.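

In this assay, putting hydrogen in place of chloro on the core of compound 3 gave a 1.8-fold lower number from compound 3 to compound 4 (0.26 log units; within the scatter), and this step can be set beside the same change on the core of compound 1: the same change on two cores in this assay, a 1.4-fold lower number (0.16 log units; within the scatter) from compound 1 to compound 2 and a 1.8-fold lower number (0.26 log units; within the scatter) from compound 3 to compound 4, 1.3-fold (0.10 log units) apart, within the scatter of two such steps. The other new pair, with 4-chlorophenyl in place of 2-chlorophenyl, gave a 1.4-fold lower number from compound 2 to compound 4 (0.15 log units; within the scatter), so this change of chloro position also cannot be told apart from repeat-measurement noise. Going by these compounds alone, the change therefore behaves alike on both cores as far as this test can tell, but with every step inside the scatter and only two pairs to compare, this does not show that removing a chloro group has any real effect on the number, nor that the result would carry to other cores.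

The compounds shown carry only chloro or hydrogen on their benzyl groups, so it remains open whether a methoxy group, an amine or a carboxylic acid on those rings would produce a step beyond the scatter. As far as these compounds go, it also remains open whether a longer chain in place of a benzyl group would do so.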